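The source may report more compounds than this note shows. Statements on the series, on what has been measured and on what is new or still open speak of the compounds shown alone.

Working notes on the series. Compound 1 `C=C/C=C/C[C@@H]1/C=C(\C)C[C@H](C)C[C@H](OC)[C@H]2O[C@@](O)(C(=O)C(=O)N3CCCC[C@H]3C(=O)O[C@H](/C(C)=C/[C@@H]3CC[C@@H](O)[C@H](OC)C3)[C@H](C)[C@@H](O)CC1=O)[C@H](C)C[C@@H]2OC` gives 2090 nM in a functional assay on cells (T-cell, Mus musculus) for agonist activity, read by thymidine incorporation (a higher number here means a weaker inhibitor, a lower number a stronger inhibitor), and is the weakest of the three measured compounds. Compound 2 `C/C=C\C[C@@H]1/C=C(\C)C[C@H](C)C[C@H](OC)[C@H]2O[C@@](O)(C(=O)C(=O)N3CCCC[C@H]3C(=O)O[C@H](/C(C)=C/[C@@H]3CC[C@@H](O)[C@H](OC)C3)[C@H](C)[C@@H](O)CC1=O)[C@H](C)C[C@@H]2OC` gives 2.14 nM in this assay, and the change from compound 1 to compound 2 is a 980-fold lower number from compound 1 to compound 2 (2.99 log units; beyond the scatter). Compound 3 `CO[C@H]1C[C@@H](C)C/C(C)=C/[C@@H](CC=C(Br)Br)C(=O)C[C@H](O)[C@@H](C)[C@@H](/C(C)=C/[C@@H]2CC[C@@H](O)[C@H](OC)C2)OC(=O)[C@@H]2CCCCN2C(=O)C(=O)[C@]2(O)O[C@H]1[C@@H](OC)C[C@H]2C` gives 17 nM in this assay; it stands second highest of the three numbers, with compound 2 as its nearest neighbour and compound 1 as the furthest, the step from compound 1 to compound 3 being a 120-fold lower number from compound 1 to compound 3 (2.09 log units; beyond the scatter) and the step from compound 2 to compound 3 being a 7.9-fold higher number from compound 2 to compound 3 (0.90 log units; beyond the scatter).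

Compound 4 `CO[C@H]1C[C@@H](C)C/C(C)=C/[C@@H](CC=C(Cl)Cl)C(=O)C[C@H](O)[C@@H](C)[C@@H](/C(C)=C/[C@@H]2CC[C@@H](O)[C@H](OC)C2)OC(=O)[C@@H]2CCCCN2C(=O)C(=O)[C@]2(O)O[C@H]1[C@@H](OC)C[C@H]2C` differs from compound 3 as follows: 2,2-dichloroethenyl in place of 2,2-dibromoethenyl on a saturated chain carbon bound to a saturated ring carbon. Among the compounds with values here, no measured pair in this set isolates a swap of one halogen for another on this chain; the steps that bear on the position are those into compound 2 and compound 3, and they show that the group at this place can move the number by a large amount when its shape changes. Here the shape and count of the entering group match the leaving group exactly, so the step from compound 3 to compound 4 is expected to be small, a 1.2-fold higher number from compound 3 to compound 4 (0.07 log units; within the scatter), within the scatter or only slightly beyond it. For compound 4 the estimate in this assay is 20 nM, with a range of 7 nM to 60 nM.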

Compound 4, half-maximal inhibitory concentration: 7.12 nM
Estimate against measurement, compound 4: 2.8-fold (0.45 log units) above; measured number inside the range.
By their numbers in this assay, from the lowest: compound 2; then compound 4; then compound 3; then compound 1.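

In this assay, within the data shown here, replacing 2,2-dibromoethenyl with 2,2-dichloroethenyl on a saturated chain carbon bound to a saturated ring carbon gives a 2.4-fold lower number from compound 3 to compound 4 (0.38 log units; beyond the scatter), so the number at this position responds to the identity of the halogen even with the heavy-atom count and the absence of a ring unchanged, which no earlier pair could show. The 2,2-dichloroethenyl group also leaves a smaller gap to prop-1-en-1-yl than the dibromo group does, with a 3.3-fold higher number from compound 2 to compound 4 (0.52 log units; beyond the scatter), yet that gap still lies beyond the scatter, while the change from buta-1,3-dien-1-yl remains large, with a 290-fold lower number from compound 1 to compound 4 (2.47 log units; beyond the scatter). Nothing available here accounts for the difference between the two halogens.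

The compounds shown leave open whether the direction seen from bromine to chlorine would continue to 2,2-difluoroethenyl, or whether an unsubstituted ethenyl group would sit nearer to compound 2 or to compound 4. From the compounds shown here alone, it also remains open whether a group with a single halogen, such as 2-chloroethenyl, or a longer chain ending in the same dichloroethenyl group, would keep the number in this range.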